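This account rests on a few compounds, and the source may have more. Where it says the series, first, only, none or still open, it means among the compounds named here.

The measured compounds in a functional assay on T47D cells (Homo sapiens) for inhibition, read by sulforhodamine B assay, with a stated time of 48 h; a higher number here means a weaker inhibitor of growth, a lower number a stronger inhibitor of growth:

compound 1, `COC(=O)[C@@]1(C)CCC=C2[C@@H]1CC[C@@H](C)[C@]2(C)Cc1c[nH]c2ccc(C)cc12`: 20000 nM
compound 2, `COC(=O)[C@@]1(C)CCC=C2[C@@H]1CC[C@@H](C)[C@]2(C)Cc1c(C)[nH]c2ccc(C)cc12`: 31000 nM
compound 3, `COC(=O)[C@@]1(C)CCC=C2[C@@H]1CC[C@@H](C)[C@]2(C)Cc1c(C)n(C(c2ccccc2)c2ccccc2)c2ccc(Cl)cc12`: > 100000 nM

Compound 1 and compound 2 share the same core and differ only in a methyl in place of a hydrogen on an aromatic carbon; the result is a 1.6-fold higher number from compound 1 to compound 2 (0.19 log units; within the scatter), so the two cannot be told apart. From the compounds shown here alone, for compound 3 this assay reports no number at all, only (the limit of > 100000 nM in this assay, at which 1 of the 3 values shown sits); where compound 3 stands within that region is unknown.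

Compound 4, `Cc1c(C[C@]2(C)C3=CCC[C@](C)(C(=O)O)[C@H]3CC[C@H]2C)c2cc(Cl)ccc2n1C(c1ccccc1)c1ccccc1`, differs from compound 3 by hydrogen in place of methyl on an oxygen next to a carbonyl group. Among the compounds with values here, no measured pair shows this change: the single measured step, a 1.6-fold higher number from compound 1 to compound 2 (0.19 log units; within the scatter), concerns a methyl on an aromatic carbon and says nothing about the ester. The only anchor is therefore the limit of compound 3. Because compound 3 gives > 100000 nM, the expectation for compound 4 is that this assay will again report only a limit or a very high number. Compound 4 is estimated at 100000 nM, with a range from 30000 nM to 300000 nM. This estimate means an expected step of a number no higher from compound 3 to compound 4 (the limit leaves the size open).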

Compound 4, concentration for 50% growth inhibition: 13000 nM
Estimate against measurement, compound 4: 7.7-fold (0.89 log units) above; the whole stated range lies above it.
By their numbers in this assay, from the lowest: compounds 4, 1 and 2 (each within the scatter of the next, the first and the last beyond it). At a limit, above all of these: compound 3.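

In this assay, replacing the methoxycarbonyl of compound 3 with a carboxy group gives an at least 7.6-fold lower number from compound 3 to compound 4 (0.88 log units; beyond the scatter). This hydrogen in place of methyl on an oxygen next to a carbonyl group is the first change shown to move the number beyond the scatter, whereas the only earlier step, a methyl on an aromatic carbon, stayed within it. The value of compound 3 is a limit and not a number, so the true size of this step remains unknown and may be larger: the limit of > 100000 nM in this assay, at which 1 of the 4 values shown sits.

From the compounds shown here alone, compound 1 and compound 2 still carry the methoxycarbonyl, so it is open whether the same change would lower their numbers too. Going by these compounds, it is also open how an amide or a hydroxymethyl group at this position would compare with the carboxy group of compound 4.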